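The source may hold more compounds than are shown below. What is called first, only, known or untested is meant among the compounds shown, and "the series" means these compounds.

Working notes on the series. In a functional assay on MCF7 cells (Homo sapiens) for inhibition, with a stated time of 96 h (on this read-out higher numbers stand for weaker inhibition and lower numbers for stronger inhibition), compound 1 (`COc1cc(C(=O)c2cn(-c3cccc(C)c3)cc2-c2nccs2)cc(OC)c1OC`) gives 20 nM and compound 2 (`COc1cc(C(=O)c2cn(-c3ccc(F)cc3)cc2-c2ccco2)cc(OC)c1OC`) gives 17 nM. Among the measured compounds shown here, these two values lie within the scatter of each other, so compound 2 stands level with compound 1 on the numbers so far.

Compound 3 (`COc1cc(C(=O)c2cn(-c3ccc(F)cc3)cc2-c2nccs2)cc(OC)c1OC`) keeps the 4-fluorophenyl group of compound 2 and has 1,3-thiazol-2-yl in place of furan-2-yl on an aromatic carbon. For the measured compounds named here, no measured pair isolates this change. Going by the values given here, the only guide is compound 1, which also carries 1,3-thiazol-2-yl and gives 20 nM in this assay.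

The expected step of a 1.2-fold higher number from compound 2 to compound 3 (0.07 log units; within the scatter) is none beyond the scatter, with no direction favoured. For compound 3 the estimated value is 20 nM, with an expected range of 8 nM to 50 nM.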

Compound 3, half-maximal inhibitory concentration: 22 nM
Estimate against measurement, compound 3: 1.1-fold (0.04 log units) below, within the range that was stated.
By their numbers in this assay, from the lowest: compounds 2, 1 and 3 (each within the scatter of the next).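

In this assay, 1,3-thiazol-2-yl in place of furan-2-yl on an aromatic carbon now has a measured pair, with a 1.3-fold higher number from compound 2 to compound 3 (0.11 log units; within the scatter) and the 4-fluorophenyl group held fixed, so no difference between these two rings can be read at this position. The second pair, 4-fluorophenyl in place of 3-methylphenyl on an aromatic nitrogen, gives a 1.1-fold higher number from compound 1 to compound 3 (0.04 log units; within the scatter) with 1,3-thiazol-2-yl held fixed, so that change also shows no readable difference. No measurement at hand offers an explanation for either result.

From the compounds shown here alone, all three compounds carry a five-membered aromatic ring at this position, so it remains open whether a carboxylic acid, an amine or a pyridin-2-yl ring there would hold the level seen in this assay. Going by these compounds, it also remains open whether the two rings stay level when the group on the ring nitrogen is a longer alkyl chain.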